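A few compounds are considered here, and "the series" means these few. Any claim that something is new, unique, unknown or untested is made for them only; others in the source may bear on it.

The series begins with compound 1 `CC(=O)OC/C(=C\c1ccccc1)C(=O)c1ccccc1`, which in a functional assay on T47D cells (Homo sapiens) for inhibition, read by sulforhodamine B assay, with a stated time of 48 h (on this read-out lower numbers stand for stronger inhibition of growth and higher numbers for weaker inhibition of growth), gives 16000 nM. Among the measured compounds shown here, compound 2 `CC(=O)OC/C(=C\c1ccc(Cl)cc1)C(=O)c1ccccc1` differs from it by chloro in place of hydrogen on an aromatic carbon and in this assay compound 2 gives 5300 nM; this step, a 3.0-fold lower number from compound 1 to compound 2 (0.48 log units; beyond the scatter), is the one change whose effect has been measured within the set. Compound 3 `CC(=O)OC/C(=C/c1ccccc1Cl)C(=O)c1ccccc1` carries its chloro group at another place; how its core differs from that of compound 1 is not broken down here. In this assay compound 3 gives 19000 nM, a number within the scatter of compound 1 and beyond the scatter from compound 2. Compound 4 `CC(=O)OC/C(=C/c1ccc(Cl)cc1Cl)C(=O)c1ccccc1` has not yet been measured. It differs from compound 3 by chloro in place of hydrogen on an aromatic carbon; the place is not identical to the earlier one, as the entering chloro is here also meta to a chloro group, so this counts as the same kind of change rather than the same change. Compound 4 is expected to show a step of a 3.0-fold lower number from compound 3 to compound 4 (0.48 log units; beyond the scatter) in this assay, because a 3.0-fold lower number from compound 1 to compound 2 (0.48 log units; beyond the scatter) lowered the number once before. Compound 4 is therefore estimated to give 6300 nM, with a plausible range from 3000 nM to 14000 nM.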

Compound 4, concentration for 50% growth inhibition: 20000 nM
The estimate for compound 4 lay 3.2-fold (0.50 log units) below the measured number, outside the stated range (above it).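

On the core of compound 3, chloro in place of hydrogen on an aromatic carbon gave a 1.1-fold higher number from compound 3 to compound 4 (0.02 log units; within the scatter), so in this assay compound 3 and compound 4 cannot be told apart. The lower number seen on the core of compound 1 therefore did not carry over to the core of compound 3, and the same change gave different results on the two cores: the same change on two cores in this assay, a 3.0-fold lower number (0.48 log units; beyond the scatter) from compound 1 to compound 2 and a 1.1-fold higher number (0.02 log units; within the scatter) from compound 3 to compound 4, 3.2-fold (0.50 log units) apart, beyond the scatter of two such steps

Among the compounds shown here, this rests on only two pairs and does not show why the steps differ: on the second core the entering chloro is meta to a chloro group, but nothing here separates that feature from any other difference between the cores. The compounds shown leave open whether another group at the same place, such as a methoxy group, a nitrile or an amine, would follow the first step or the second. Also open, as far as these compounds go, is whether a carboxylic acid or a longer chain elsewhere on these cores would bring the two results closer together or push them further apart.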